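Swapping a halogen on the aryl ring of a pyrimidinone nitrile

The compounds below may be only part of what the source reports. "The series", "measured", "known", "first", "only" and "open" are said of these compounds alone.

Of the compounds shown here, two sharing a nitrile-bearing core have been tested in a functional assay, with a stated time of 150 min; a higher number here means a weaker inhibitor, a lower number a stronger inhibitor. Compound 1 `COc1cccc(-c2nc(SC)n(C)c(=O)c2C#N)c1OC` carries two methoxy groups on its aryl ring and a methylthio group on the core; in this assay compound 1 gives 67 ug/mL. Compound 2 `Cn1c(NN)nc(-c2ccccc2F)c(C#N)c1=O` instead carries a hydrazino group on the core and a single fluoro on the aryl ring; in this assay compound 2 gives 60 ug/mL. These two numbers lie within the usual scatter of each other, so neither compound can be called the stronger or the weaker inhibitor on this evidence.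

Compound 3 `Cn1c(NN)nc(-c2ccccc2Cl)c(C#N)c1=O` has not yet been measured. It differs from compound 2 in one place: chloro in place of fluoro on an aromatic carbon. Among the measured compounds shown here, nothing measured so far shows what such a swap does here, and the change is small in atom count. The step from compound 2 to compound 3 is therefore expected to stay within the scatter, with a 1.1-fold lower number from compound 2 to compound 3 (0.04 log units; within the scatter). For compound 3 the estimated result in this assay is 55 ug/mL, with a range from 28 ug/mL to 110 ug/mL.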

Compound 3, half-maximal inhibitory concentration: 62 ug/mL
Estimate against measurement, compound 3: 1.1-fold (0.05 log units) below, within the range that was stated.
By their numbers in this assay, from the lowest: compounds 2, 3 and 1 (each within the scatter of the next).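

Among the compounds shown here, compounds 2 and 3 are the first pair here that differ in only one place, so this is the first reading of a single change; compounds 1 and 2 differ in both the aryl ring and the group on the core. In this assay chloro in place of fluoro on an aromatic carbon, ortho to a large group, gives a 1.0-fold higher number from compound 2 to compound 3 (0.01 log units; within the scatter) and so, with the hydrazino group held fixed on the shared core, these two halogens cannot be told apart at this position. No other measurement shown here bears on this result, so it stands as an observation without an explanation.

From the compounds shown here alone, whether the number at this position would move with a group other than a halogen, such as a methyl, an amine or a carboxylic acid, or with only hydrogen there, remains open. Also open, going by these compounds, is whether the same halogen swap would read alike with a methylthio group on the core in place of the hydrazino group, or in any other assay.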